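The compounds below may be only part of what the source reports. "The series", "measured", "known", "first", "only" and "open" are said of these compounds alone.

Measured in an ADME assay on Vero cells (Chlorocebus sabaeus) for cytotoxicity, read by sulforhodamine B assay, with a stated time of 72 h; a higher number here means a weaker inhibitor, a lower number a stronger inhibitor:

compound 1 `CN1Cc2ccc(O)cc2[C@@H](OCc2ccccc2)C1`: > 50000 nM.
compound 2 `CN1Cc2ccc(O)cc2[C@@H](OCc2ccc(-c3ccccc3)cc2)C1`: > 50000 nM.
compound 3 `OC1CCCc2ccc(OCc3ccccc3)cc21`: 39000 nM.

For compound 1 the value in this assay is a limit of the assay and not a number. For compound 2 the value in this assay is likewise a limit and not a number. Compound 3 is the only one of the three with a number; how its core differs from the core of compound 1 is not broken down here.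

Compound 1 and compound 2 differ by one change, (phenyl in place of hydrogen on an aromatic carbon), and in this assay this gives a step that the two limits leave unreadable from compound 1 to compound 2. The reason the step cannot be read is the limit of > 50000 nM in this assay, at which 2 of the 3 values shown sit.

Compound 4 `OC1CCCc2ccc(OCc3ccc(-c4ccccc4)cc3)cc21` has not yet been measured. Within the data shown here, it differs from compound 3 by phenyl in place of hydrogen on an aromatic carbon, the same change as the one from compound 1 to compound 2. Since compound 3 starts from a number, 39000 nM, the step to compound 4 can in principle be read, unlike the step from compound 1 to compound 2.

In this assay the step from compound 3 to compound 4 is expected to be small, a 1.1-fold lower number from compound 3 to compound 4 (0.05 log units; within the scatter), an expectation that rests on the measured value of compound 3 and on the fact that the same change gave a step that the two limits leave unreadable from compound 1 to compound 2, so the direction of the change is not established. Compound 4 is therefore estimated to give about 35000 nM in this assay, most likely between 12000 nM and 100000 nM.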

Compound 4, half-maximal inhibitory concentration: > 100000 nM
Compound 4 ended at the assay's limit; the forecaster's own chance of this, stated with the estimate: 40%; middle value at least 2.8-fold (0.45 log units) away from the limit.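

In this assay, phenyl in place of hydrogen on an aromatic carbon gives an at least 2.5-fold higher number from compound 3 to compound 4 (0.40 log units; beyond the scatter), so on the core of compound 3 the change makes for a weaker inhibitor, and by more than repeated measurements would scatter. Compound 4 gives > 100000 nM, which is a limit of the assay and not a number, so the true size of this step could be larger than the figure printed. This does not show that the change carries from one core to another, since one readable pair is a single case, and the same change on the core of compound 1 cannot be read, because both partners there stop at a limit: the limit of > 50000 nM in this assay, at which 2 of the 4 values shown sit.

The compounds shown leave open whether the step on the core of compound 1 runs the same way and how large the step on the core of compound 3 really is, which would take a number for compound 4 in place of its limit. They also leave open how an amine, a carboxylic acid or a longer chain at the same place on the core of compound 3 would read in this assay.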